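A few compounds are considered here, and "the series" means these few. Any claim that something is new, unique, unknown or untested is made for them only; others in the source may bear on it.

Compound 2 `COc1cc(-c2cc(/C=C/C(=O)c3ccc(Cl)c(Cl)c3)[nH]n2)cc(OC)c1OC` is the starting point of this step. In a functional assay on IGROV-1 cells (Homo sapiens) for inhibition, read by sulforhodamine B assay, with a stated time of 48 h (on this read-out lower numbers stand for stronger inhibition of growth and higher numbers for weaker inhibition of growth), compound 2 gives only a limit, > 100000 nM, and no number. Its close relative compound 1 `COc1cc(-c2cc(/C=C/C(=O)c3ccc(N)cc3)[nH]n2)cc(OC)c1OC` gives 10500 nM in this assay, so the step is an at least 9.5-fold higher number from compound 1 to compound 2 (0.97 log units; beyond the scatter), with compound 2 sitting at the limit of > 100000 nM in this assay, at which 1 of the 3 values shown sits. Compound 3 `COc1ccc(-c2cc(/C=C/C(=O)c3cc(OC)c(OC)c(OC)c3)[nH]n2)cc1OC`, which differs elsewhere in the molecule, gives 8610 nM in this assay. The change to compound 4 `COc1ccc(C(=O)/C=C/c2cc(-c3cc(OC)c(OC)c(OC)c3)n[nH]2)cc1` is 4-methoxyphenyl in place of 3,4-dichlorophenyl on a carbonyl carbon. Going by the values given here, only the step from compound 1 to compound 2 bears on it, and it suggests that removing the 3,4-dichlorophenyl should bring the number back down; the expected step is an at least 6.6-fold lower number from compound 2 to compound 4 (0.82 log units; beyond the scatter). Compound 4 is therefore expected to give about 15000 nM in this assay, within a range of 3000 nM to 80000 nM.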

Compound 4, concentration for total growth inhibition: 4810 nM
For compound 4 the middle estimate is 3.1-fold (0.49 log units) above the measured one, and the stated range covers the measured number.
By their numbers in this assay, from the lowest: compounds 4, 3 and 1 (each within the scatter of the next, the first and the last beyond it). At a limit, above all of these: compound 2.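

With 4-methoxyphenyl in place of 3,4-dichlorophenyl on the carbonyl carbon, this assay shows an at least 20-fold lower number from compound 2 to compound 4 (1.31 log units; beyond the scatter), so the poor result of compound 2 does not extend to every substituted phenyl at this place. Methoxy in place of amino on the aromatic carbon gives a 2.2-fold lower number from compound 1 to compound 4 (0.34 log units; beyond the scatter), so the amino group of compound 1 is not required for this level of growth inhibition. Compound 2 gives a limit and no number: the limit of > 100000 nM in this assay, at which 1 of the 4 values shown sits.

Going by these compounds, how a hydroxy group, a carboxylic acid or a single chlorine on that aromatic carbon would read in this assay remains open.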